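The source may report more compounds than this note shows. Statements on the series, on what has been measured and on what is new or still open speak of the compounds shown alone.

Working notes on the series. Three compounds carry numbers in a functional assay on CAKI-1 cells (Homo sapiens) for inhibition, read by sulforhodamine B assay, with a stated time of 48 h; on this read-out higher numbers stand for weaker inhibition of growth and lower numbers for stronger inhibition of growth. Compound 1 `COc1ccc(-c2[nH]c3ccccc3c2/C=C(\C#N)S(=O)(=O)c2ccccc2)cc1` gives 997 nM in this assay. Compound 2 `COc1ccc2[nH]c(-c3ccccc3)c(C=C(C#N)C#N)c2c1` gives 4100 nM, and compound 3 `CCOC(=O)C(=Cc1c(-c2ccccc2)[nH]c2ccccc12)C(=O)OCC` gives 10300 nM. Compound 1 thus stands lowest of the three; the numbers of compound 2 and compound 3 lie higher than that of compound 1, and both gaps are beyond the usual scatter of repeated measurements, so compound 1 is the strongest growth inhibitor among the measured compounds.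

Compound 4 `COc1ccc(-c2[nH]c3ccc(OC)cc3c2/C=C(\C#N)S(=O)(=O)c2ccccc2)cc1` is not yet measured. It differs from compound 1 in one place: methoxy in place of hydrogen on an aromatic carbon. Among the compounds with values here, no pair of measured compounds that differ only in this way is available, so the size of the step has to be guessed. Compound 2 also carries a methoxy on the fused ring system, but it differs from compound 1 in several other places as well, so its number cannot be read as a test of this change. The expected step from compound 1 to compound 4 in this assay is a 1.0-fold higher number from compound 1 to compound 4 (0.00 log units; within the scatter), which is taken as small and within the scatter. Compound 4 is estimated at 1000 nM, with a range from 400 nM to 2500 nM.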

Compound 4, concentration for 50% growth inhibition: 4200 nM
Beside the measured number, compound 4's estimate is 4.2-fold (0.62 log units) below it, outside the stated range (above it).
By their numbers in this assay, from the lowest: compound 1; then compounds 2 and 4 (each within the scatter of the next); then compound 3.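

In this assay this position does not tolerate substitution without consequence: methoxy in place of hydrogen on this aromatic carbon gives a 4.2-fold higher number from compound 1 to compound 4 (0.62 log units; beyond the scatter), a change toward weaker inhibition of growth. Within the data shown here, this is the first step between compounds that differ in one place, so the effect of this change now rests on a measured pair, though on that single pair only. Nothing in the data shown accounts for the size or direction of the step.

On these data alone, whether the weaker inhibition belongs to methoxy specifically or would also follow another group at this position, such as hydroxyl, fluorine or an amine, remains open. Also open, as far as these compounds go, is whether methoxy at another aromatic carbon of the core would give a similar step.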